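The source may report more compounds than this note shows. Statements on the series, on what has been measured and on what is new or still open speak of the compounds shown alone.

Compound 1 `CC(C)C[C@H](N)CN(C(=O)[C@@H]1C[C@H]1c1ccccc1)c1ccc(-c2ccsc2)cc1` in a functional assay for agonist activity at G protein-coupled receptor 88 (Homo sapiens), read by HTRF and cAMP accumulation (on this read-out higher numbers stand for an effect only at larger amounts of compound and lower numbers for an effect already at smaller amounts), gives 1200 nM. Compound 2 `Cc1ccc(-c2ccc(N(C[C@@H](N)CC(C)C)C(=O)[C@@H]3C[C@H]3c3ccccc3)cc2)cc1` gives 360 nM. Compound 3 `COc1ccc(-c2ccc(N(C[C@@H](N)CC(C)C)C(=O)[C@@H]3C[C@H]3c3ccccc3)cc2)cc1` gives 330 nM.

Compound 3 stands at the low end of these numbers: the step of a 3.6-fold lower number from compound 1 to compound 3 (0.56 log units; beyond the scatter) is clear, whereas compounds 2 and 3 cannot be told apart. Compound 4 `CC(C)C[C@H](N)CN(C(=O)[C@@H]1C[C@H]1c1ccccc1)c1ccc(-c2ccc(Cl)cc2)cc1` differs from compound 3 by chloro in place of methoxy on an aromatic carbon. Among the measured compounds shown here, the only measured step bearing on this place is a 1.1-fold lower number from compound 2 to compound 3 (0.04 log units; within the scatter), which exchanged one small group for another at the same position without a shift. No chloro group has been measured here, so this expectation rests on one comparison. Compound 4 is expected to give 350 nM in this assay. The expected step is a 1.1-fold higher number from compound 3 to compound 4 (0.03 log units; within the scatter), essentially none beyond the scatter. The estimated range for compound 4 runs from 150 nM to 800 nM.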

Compound 4, half-maximal effective concentration: 640 nM
The estimate for compound 4 lay 1.8-fold (0.26 log units) below the measured number; low and high end bracket the measured number.
By their numbers in this assay, from the lowest: compounds 3, 2, 4 and 1 (each within the scatter of the next, the first and the last beyond it).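

In this assay chloro on this ring, para to a large group, gives a 1.9-fold higher number from compound 3 to compound 4 (0.29 log units; within the scatter) and a 1.8-fold higher number from compound 2 to compound 4 (0.25 log units; within the scatter) so it cannot be told apart from methoxy or methyl at this place. The change to 4-chlorophenyl from thiophen-3-yl gives a 1.9-fold lower number from compound 1 to compound 4 (0.27 log units; within the scatter) so compound 4 lies within the scatter of both compound 1 and compound 3, even though those two stand apart. No measurement at hand explains these numbers.

As far as these compounds go, what an amine, a carboxylic acid or a longer chain would do at this place stays open. So does whether any group here can move the number clearly away from that of methoxy.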